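Shortening the chain of compound 3

The source may report more compounds than this note shows. Statements on the series, on what has been measured and on what is new or still open speak of the compounds shown alone.

Values in a functional assay on MCF7 cells (Homo sapiens) for inhibition, read by MTT assay, with stated times of 18 h and 4 h (on this read-out higher numbers stand for weaker inhibition and lower numbers for stronger inhibition), by compound:
compound 1 `CCCCCCCCCCCCCCCCOP(=O)(O)OCCSC(=S)N1CCCCCC1` gives > 100000 nM as a limit of the assay
compound 2 `CCCCCCCCOP(=O)(O)OCCSC(=S)N1CCCCC1` gives 26000 nM as a number
compound 3 `CCCCCCCCCCCCCCCCOP(=O)(O)OCCSC(=S)N1CCN(C)CC1` gives > 100000 nM as a limit of the assay

Compound 3 has only a limit and no number in this assay and sits with compound 1 at the limit of > 100000 nM in this assay, at which 2 of the 3 values shown sit, on this scale. Compound 4 `CCCCCCCCOP(=O)(O)OCCSC(=S)N1CCN(C)CC1` has hydrogen in place of octyl on a saturated chain carbon, eight bonds along the chain from an oxygen on an unsaturated carbon, and the difference counts as hydrogen in place of octyl on a saturated chain carbon, eight bonds along the chain from an oxygen on an unsaturated carbon with nothing else altered.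

Among the compounds with values here, the one measured step is a step that the two limits leave unreadable from compound 1 to compound 3 and it lends no size to this change, since it lies in another part of the molecule. The nearest guide is compound 2, which shares the shorter chain of compound 4 but differs in the group on the thiocarbonyl carbon. Going by compound 2 at 26000 nM in this assay a measurable number is expected for compound 4. The expected move is an at least 3.3-fold lower number from compound 3 to compound 4 (0.52 log units; beyond the scatter) towards stronger inhibition, with its full size left open. Compound 4 is expected at 30000 nM with an estimated range from 10000 nM to 100000 nM in this assay.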

Compound 4, half-maximal inhibitory concentration: 46000 nM
For compound 4 the middle estimate is 1.5-fold (0.19 log units) below the measured one; the range from low to high includes it.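

In this assay, within the data shown here, hydrogen in place of octyl on a saturated chain carbon, eight bonds along the chain from an oxygen on an unsaturated carbon, gives an at least 2.1-fold lower number from compound 3 to compound 4 (0.33 log units; beyond the scatter), the first readable effect of this change at this position and the first number for a compound carrying 4-methylpiperazin-1-yl. With the shorter chain held constant, changing the group on the thiocarbonyl carbon gives a 1.8-fold higher number from compound 2 to compound 4 (0.25 log units; within the scatter), so these two groups cannot be told apart in this assay. The full size of the chain step stays open because compound 3 has only a limit and no number: the limit of > 100000 nM in this assay, at which 2 of the 4 values shown sit.

As far as these compounds go, the step from compound 1 to compound 3 cannot be read, so the effect of the thiocarbonyl group on the longer chain remains unknown. The compounds shown leave open how the read-out behaves with a dodecyl chain or a butyl chain, and whether morpholin-4-yl on the thiocarbonyl carbon of the shorter-chain series would give a number distinct from those of compound 2 and compound 4.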